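This account rests on a few compounds, and the source may have more. Where it says the series, first, only, none or still open, it means among the compounds named here.

Three compounds have been measured in a functional assay on MCF7 cells (Homo sapiens) for inhibition, read by MTT assay; on this read-out lower numbers stand for stronger inhibition and higher numbers for weaker inhibition:

Compound 1, `O=C(CBr)Nc1ccc(C(=O)/C=C/c2cn(Cc3ccc(Br)cc3)nn2)cc1`, gives 10100 nM.
Compound 2, `CCCCCCCCCCn1cc(/C=C/C(=O)c2ccc(NC(=O)CN3CCN(c4ccccc4)CC3)cc2)nn1`, reaches only the limit of this assay, > 100000 nM.
Compound 3, `CCCCCCCCn1cc(/C=C/C(=O)c2ccc(NC(=O)CBr)cc2)nn1`, gives 12900 nM.

Compound 3 and compound 1 sit within the scatter of each other: a 1.3-fold higher number from compound 1 to compound 3 (0.11 log units; within the scatter). Compound 2 stands apart as a limit, (the limit of > 100000 nM in this assay, at which 1 of the 3 values shown sits), so it contributes no number to compare against.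

Compound 4, `CCCCCCCCCCn1cc(/C=C/C(=O)c2ccc(NC(=O)CBr)cc2)nn1`, has not yet been measured in this assay. It differs from compound 3 as follows: ethyl in place of hydrogen on a saturated chain carbon, eight bonds along the chain from an aromatic nitrogen. Within the data shown here, the only measured step, from compound 1 to compound 3, exchanged the whole group on the chain carbon bound to the aromatic nitrogen and moved the number by a 1.3-fold higher number from compound 1 to compound 3 (0.11 log units; within the scatter), which lies within the scatter. No measured step lengthens the chain itself, so the data give no reason to expect a shift beyond the scatter in either direction. The step from compound 3 to compound 4 is therefore estimated as a 1.0-fold higher number from compound 3 to compound 4 (0.00 log units; within the scatter). Compound 4 is expected to give about 13000 nM, within a range from 5000 nM to 40000 nM.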

Compound 4, half-maximal inhibitory concentration: 9760 nM
Estimate against measurement, compound 4: 1.3-fold (0.12 log units) above; measured number inside the range.
By their numbers in this assay, from the lowest: compounds 4, 1 and 3 (each within the scatter of the next). At a limit, above all of these: compound 2.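

In this assay, the ethyl added on a saturated chain carbon, eight bonds along the chain from an aromatic nitrogen, gives the first measured lengthening of the chain itself, and the change lies within the scatter (a 1.3-fold lower number from compound 3 to compound 4 (0.12 log units; within the scatter)); the nonyl group in place of 4-bromophenyl also leaves the two numbers within the scatter (a 1.0-fold lower number from compound 1 to compound 4 (0.01 log units; within the scatter)). The large change appears instead at the other end of the molecule, where the same chain is kept and bromo stands in place of 4-phenylpiperazin-1-yl on the saturated chain carbon bound to a carbonyl carbon (an at least 10-fold lower number from compound 2 to compound 4 (1.01 log units; beyond the scatter)). The value of compound 2 is a limit, not a number: the limit of > 100000 nM in this assay, at which 1 of the 4 values shown sits.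

Still open, as far as these compounds go, is whether a much shorter chain such as butyl would hold the number as these chains do. Also open, from the compounds shown here alone, is what a chloro or dimethylamino group would give in place of bromo.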